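The compounds below may be only part of what the source reports. "The series", "measured", "known", "first", "only" and "open" are said of these compounds alone.

Three esters of the same core were compared in one assay. Compound 1 `N[C@@H](CC(=O)OC[C@H]1O[C@@H](n2cc(F)c(=O)[nH]c2=O)C[C@@H]1O)C(=O)O` gives 820000 nM in an assay on cells (Oocyte) for inhibition of sodium- and chloride-dependent neutral and basic amino acid transporter B(0+) (Homo sapiens), read by LC-MS, with a stated time of 10 min (on this read-out lower numbers stand for stronger inhibition and higher numbers for weaker inhibition), compound 3 `N[C@@H](CCC(=O)OC[C@H]1O[C@@H](n2cc(F)c(=O)[nH]c2=O)C[C@@H]1O)C(=O)O` gives 1130000 nM, and compound 2 `N[C@@H](CCC(=O)O[C@H]1C[C@H](n2cc(F)c(=O)[nH]c2=O)O[C@@H]1CO)C(=O)O` gives 1840000 nM, the highest of the three numbers: compound 3 stands nearest to it, within the scatter, while compound 1 stands furthest, beyond it. Compound 4 `N[C@@H](CC(=O)O[C@H]1C[C@H](n2cc(F)c(=O)[nH]c2=O)O[C@@H]1CO)C(=O)O` differs from compound 2 in a single place: amino(carboxy)methyl in place of 2-amino-2-carboxyethyl on a saturated chain carbon bound to a carbonyl carbon. Among the compounds with values here, only one measured step bears on this change, and it runs the opposite way: a 1.4-fold higher number from compound 1 to compound 3 (0.14 log units; within the scatter). Read backwards, compound 4 is expected to show a 1.4-fold lower number from compound 2 to compound 4 (0.15 log units; within the scatter), a shift that stays within the scatter. Compound 4 is accordingly estimated at 1300000 nM, with a range from 500000 nM to 3500000 nM.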

Compound 4, half-maximal inhibitory concentration: 1570000 nM
For compound 4 the middle estimate is 1.2-fold (0.08 log units) below the measured one; low and high end bracket the measured number.
By their numbers in this assay, from the lowest: compounds 1, 3, 4 and 2 (each within the scatter of the next, the first and the last beyond it).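

The change from 2-amino-2-carboxyethyl to amino(carboxy)methyl on a saturated chain carbon bound to a carbonyl carbon now has a reading on a second core in this assay, with a 1.2-fold lower number from compound 2 to compound 4 (0.07 log units; within the scatter). Earlier it had been read on one core only, and now neither reading leaves the scatter, so this change makes no readable difference at this position on either core, and the two readings agree: the same change on two cores in this assay, a 1.4-fold higher number (0.14 log units; within the scatter) from compound 1 to compound 3 and a 1.2-fold higher number (0.07 log units; within the scatter) from compound 4 to compound 2, 1.2-fold (0.07 log units) apart, within the scatter of two such steps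

On these data alone, whether a longer chain at this place would shift the number beyond the scatter remains open. So does the effect of an amide in place of the ester.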